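This account rests on a few compounds, and the source may have more. Where it says the series, first, only, none or still open, it means among the compounds named here.

Working notes on the uracil-derived diphosphate series, an in vitro functional assay on 1321-N1 cells for agonist activity at P2Y purinoceptor 2 (Homo sapiens), read by scintillation proximity assay and inositol phosphate accumulation; on this read-out higher numbers stand for an effect only at larger amounts of compound and lower numbers for an effect already at smaller amounts.

Three analogues carry the measurement so far. Compound 1 `Nc1nc(=O)ccn1[C@@H]1O[C@H](COP(=O)(O)OP(=O)(O)O)[C@@H](O)[C@H]1O` gives 604 nM in this assay. Compound 2 `CCCSc1nc(=O)ccn1[C@@H]1O[C@H](COP(=O)(O)OP(=O)(O)O)[C@@H](O)[C@H]1O` gives 1200 nM. Compound 3 `COc1nc(=O)ccn1[C@@H]1O[C@H](COP(=O)(O)OP(=O)(O)O)[C@@H](O)[C@H]1O` gives 907 nM, and sits second highest of the three numbers, its nearest neighbour being compound 2 and its furthest compound 1, both gaps within the scatter. The steps among them are small: a 2.0-fold higher number from compound 1 to compound 2 (0.30 log units; within the scatter), a 1.5-fold higher number from compound 1 to compound 3 (0.18 log units; within the scatter) and a 1.3-fold lower number from compound 2 to compound 3 (0.12 log units; within the scatter), none beyond the scatter.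

Compound 4 `CNc1nc(=O)ccn1[C@@H]1O[C@H](COP(=O)(O)OP(=O)(O)O)[C@@H](O)[C@H]1O` is next: methylamino in place of methoxy on an aromatic carbon. The step that bears most directly is the exchange of amino for methoxy, a 1.5-fold higher number from compound 1 to compound 3 (0.18 log units; within the scatter), since methylamino shares the donor of amino and the single carbon of methoxy; the exchange a 1.3-fold lower number from compound 2 to compound 3 (0.12 log units; within the scatter) adds that a change of the substituent on this carbon has so far moved the number little. No step beyond the scatter is therefore expected in this assay for compound 4, the estimated change being a 1.2-fold lower number from compound 3 to compound 4 (0.08 log units; within the scatter). Compound 4 is expected to give about 750 nM, with a range of 350 nM to 1600 nM.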

Compound 4, half-maximal effective concentration: 7600 nM
Compound 4: middle estimate off by 10-fold (1.01 log units), on the low side; the measured number lies above the stated range.
By their numbers in this assay, from the lowest: compounds 1, 3 and 2 (each within the scatter of the next); then compound 4.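

Among amino, methoxy and propylsulfanyl, the substituent on this aromatic carbon between two ring nitrogen atoms had not moved the number in this assay beyond the scatter, whereas methylamino does so against all three: an 8.4-fold higher number from compound 3 to compound 4 (0.92 log units; beyond the scatter), a 6.3-fold higher number from compound 2 to compound 4 (0.80 log units; beyond the scatter) and a 13-fold higher number from compound 1 to compound 4 (1.10 log units; beyond the scatter). The last of these is the largest and comes from a methyl in place of hydrogen on the nitrogen, so this exchange matters more here than any other shown, and the number does not follow chain length, since the longer propylsulfanyl stays within the scatter of amino and methoxy. Nothing available accounts for this rise.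

On these data alone, whether the rise extends to other substituted amines stays open. Ethylamino or dimethylamino on the same carbon would show whether it is specific to methylamino.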